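Methyl on the Pendant Phenyl in Two Thiazole Cores

A few compounds are considered here, and "the series" means these few. Any claim that something is new, unique, unknown or untested is made for them only; others in the source may bear on it.

The measured compounds and their values:

Compound 1, `O=C1N/C(=N/c2csc(-c3ccc(Cl)cc3)c2)S/C1=C\c1ccccc1`: > 50000 nM
Compound 2, `Cc1ccc(/C=C2\S/C(=N\c3csc(-c4ccc(Cl)cc4)c3)NC2=O)cc1`: 1500 nM
Compound 3, `COc1cccc(N2C(=O)CS/C2=N\c2csc(-c3ccccc3)c2)c1`: "not determined" (no result reported)

In a functional assay on SW-620 cells (Homo sapiens) for cytotoxicity, read by MTT assay, with a stated time of 72 h (on this read-out lower numbers stand for stronger inhibition and higher numbers for weaker inhibition), compound 1 gives only a limit, > 50000 nM. Compound 2 gives 1500 nM in this assay. The two share one core and differ by methyl in place of hydrogen on an aromatic carbon, which brings an at least 33-fold lower number from compound 1 to compound 2 (1.52 log units; beyond the scatter). Compound 1 sits at the limit of > 50000 nM in this assay, at which 1 of the 3 values shown sits.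

Compound 4, `COc1cccc(N2C(=O)CS/C2=N\c2csc(-c3ccc(C)cc3)c2)c1`, is not yet measured. It differs from compound 3 by methyl in place of hydrogen on an aromatic carbon. The difference between the cores of compound 3 and compound 1 is not broken down here. For compound 3 no number is reported in this assay, so the step from compound 3 to compound 4 has no measured anchor; the change itself is the same change as from compound 1 to compound 2, and the two place descriptions read the same word for word. Because compound 1 sits at the limit of > 50000 nM in this assay, at which 1 of the 3 values shown sits, the measured step is only a lower bound, and the size carried over to compound 4 is uncertain.

The estimated value of compound 4 in this assay is 5000 nM, expected to fall between 500 nM and 50000 nM.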

Compound 4, half-maximal inhibitory concentration: > 50000 nM
Compound 4 gave a limit, no number; the forecaster's own chance of this, stated with the estimate: 30%; middle value at least 10-fold (1.00 log units) from the limit.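

In this assay compound 4 gives > 50000 nM, which is a limit and not a number. Compound 3 has no reported result there, so no step can be read between compound 3 and compound 4. The compounds shown leave open whether methyl on the pendant phenyl does in the core of compound 3 what it does in the other core, where the change brings an at least 33-fold lower number from compound 1 to compound 2 (1.52 log units; beyond the scatter).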